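The source may hold more compounds than are shown below. What is called first, only, known or untested is meant among the compounds shown, and "the series" means these compounds.

Compound 1 `CCC(=O)c1c(C)nn(CCCN2CCN(c3ccc(C)cc3)CC2)c(=O)c1N`: 40%
Compound 2 `Cc1c(C#N)c(-c2ccccc2)nn1CCCN1CCN(c2ccc(F)cc2)CC1`: 28%

Going by the values given here, in a functional assay on the whole organism (Abdomen, strain Swiss) for inhibition, with Mus musculus as the target, with stated times of 30 min, 10 min and 5 min, at a dose of 20 mg/kg by the oral route (on this read-out higher numbers stand for a stronger effect at the one dose given and lower numbers for a weaker effect), compound 2 gives 28%, the lower of the two numbers measured so far; compound 1 gives 40%, and the gap between them lies beyond the scatter. Compound 3 `Cc1c(C#N)c(-c2ccccc2)nn1CCCN1CCN(c2ccc([N+](=O)[O-])cc2)CC1` differs from compound 2 by nitro in place of fluoro on an aromatic carbon. Among the compounds with values here, no measured pair carries this same change, so the step expected from it, a number 2 percentage points higher from compound 2 to compound 3 (within the scatter), is judged to be no larger than the scatter, with no clear direction. On that basis compound 3 is estimated at 30%, within a range from 15% to 45%.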

Compound 3, a percentage reported as inhibition, in the whole organism at one dose (the size of the read-out at that dose, not a potency): 21%
Beside the measured number, compound 3's estimate is 9 percentage points above it; low and high end bracket the measured number.
By their numbers in this assay, from the lowest: compounds 3 and 2 (each within the scatter of the next); then compound 1.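

In this assay, nitro in place of fluoro on this aromatic carbon, para to a large group, gives a number 7 percentage points lower from compound 2 to compound 3 (within the scatter). Going by these compounds alone, this is the first reading at this position: the exchange of fluoro for the larger nitro, which brings hydrogen-bond acceptors, leaves the read-out within the scatter, so the position shows no clear response to this change. Nothing measured here bears on why this is so. The compounds shown leave open how an amine or a carboxylic acid at this position would read, and whether the same change would give a similar step on the core of compound 1.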